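The compounds below may be only part of what the source reports. "The series", "measured", "known", "first", "only" and "open" are said of these compounds alone.

Two related compounds have been measured so far in an ADME assay on Vero cells (Chlorocebus sabaeus) for cytotoxicity, read by MTT assay, with a stated time of 96 h (a higher number here means that more compound is tolerated, a lower number that less compound is tolerated), so far: compound 1 `COc1ccc(-c2nc3cc(C(C)=O)ccc3n2C2CCCCC2)c(OC)c1` at 70000 nM and compound 2 `COc1ccc(-c2nc3cc(/C(C)=N/NC(N)=S)ccc3n2C2CCCCC2)cc1` at 40000 nM on the same read-out. These two numbers lie within the usual scatter of each other, so the data do not separate compound 2 from compound 1. Compound 3 `COc1ccc(-c2nc3cc(/C(C)=N/NC(N)=S)ccc3n2C2CCCCC2)c(OC)c1` is compound 2 with a single change methoxy in place of hydrogen on an aromatic carbon that turns 4-methoxyphenyl into 2,4-dimethoxyphenyl. Within the data shown here, no measured pair shows this change by itself, so any expectation here is tentative. Though it differs from compound 3 elsewhere on the shared core, compound 1 already carries 2,4-dimethoxyphenyl and gives 70000 nM with that group in place. On that basis the expected step of a 1.1-fold higher number from compound 2 to compound 3 (0.05 log units; within the scatter) stays within the scatter, with no direction favoured. The estimate for compound 3 is 45000 nM with an expected range from 18000 nM to 100000 nM once it is measured.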

Compound 3, half-maximal cytotoxic concentration: 20000 nM
Compound 3: the middle estimate sits 2.3-fold (0.35 log units) above what was measured, and the stated range covers the measured number.
By their numbers in this assay, from the lowest: compounds 3, 2 and 1 (each within the scatter of the next, the first and the last beyond it).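

In this assay, methoxy in place of hydrogen, which turns 4-methoxyphenyl into 2,4-dimethoxyphenyl, gives a 2.0-fold lower number from compound 2 to compound 3 (0.30 log units; within the scatter), so the data cannot separate the two compounds and this spot, ortho to a large group, accepts the methoxy without a clear difference. Among these compounds, the first step beyond the scatter comes from the other site: with 2,4-dimethoxyphenyl held constant, a group of 7 heavy atoms in place of a group of 3 heavy atoms gives a 3.5-fold lower number from compound 1 to compound 3 (0.54 log units; beyond the scatter), a modest step. No measurement here explains either step.

The compounds shown leave open whether a larger ethoxy or a fluorine at the same spot would also stay within the scatter. They also leave open how an amine or a carboxylic acid would read at the other site.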